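The source may report more compounds than this note shows. Statements on the series, on what has been measured and on what is new or still open speak of the compounds shown alone.

Of the compounds shown here, two of a shared core have been measured in an assay on CHO cells for displacement of a labelled ligand from adenosine receptor A3 (Homo sapiens), read by scintillation counting, with a stated time of 120 min, tested at 10 uM (a lower number here means less inhibition, a higher number more inhibition at the concentration tested (going by the name of the read-out)), so far. Compound 1, `Nc1scc(CN2CCN(c3ccccc3C(F)(F)F)CC2)c1C(=O)c1ccc(Cl)cc1`, gives 0% in this assay, and compound 2, `Nc1scc(CN2CCN(c3cccc4ccccc34)CC2)c1C(=O)c1ccc(Cl)cc1`, gives 0%. The step of no change at the digits printed from compound 1 to compound 2 (within the scatter) shows that swapping one aryl group for another on the ring nitrogen left the read-out flat. Compound 2 therefore stands level with compound 1, and neither shows any measurable displacement of the labelled ligand at the concentration tested.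

Compound 3, `Nc1scc(CN2CCN(c3ccc(F)cc3F)CC2)c1C(=O)c1ccc(Cl)cc1`, is not yet measured. It differs from compound 2 in one place: 2,4-difluorophenyl in place of naphthalen-1-yl on an amine nitrogen in a ring. For the measured compounds named here, the only step that bears on this change is the one from compound 1 to compound 2, which was within the scatter, so the expected step of a number 2 percentage points higher from compound 2 to compound 3 (within the scatter) is likewise none beyond the scatter. For compound 3 the estimated value is 2%, with a range from -8% to 15%.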

Compound 3, a percentage reported as inhibition, at one concentration (the size of the read-out at that concentration, not a potency): 0%
For compound 3 the middle estimate is 2 percentage points above the measured one; low and high end bracket the measured number.
By their numbers in this assay, from the lowest: compounds 1, 2 and 3 (each within the scatter of the next).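

Moving from two aromatic rings to one at this place, in this assay, gives no change at the digits printed from compound 2 to compound 3 (within the scatter), so replacing naphthalen-1-yl with the smaller 2,4-difluorophenyl does not bring out any inhibition. Fluorine as the ring substituent also fares no differently from trifluoromethyl, with no change at the digits printed from compound 1 to compound 3 (within the scatter), which extends the flat result from a pair of aryl groups to three on the same ring nitrogen. Nothing measured here explains why the read-out stays flat.

On these data alone, whether a benzyl group, a 2-methoxyphenyl group or a pyridin-2-yl group on this nitrogen would give any inhibition remains open. So does whether replacing the chlorine on the shared core with a methoxy group would change the read-out, since identical values give no ranking of the groups shown.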